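Benzimidazole in place of a pyridyl amide on a shared core

The compounds below may be only part of what the source reports. "The series", "measured", "known", "first", "only" and "open" are said of these compounds alone.

Compound 2 `O=C(Nc1ccccn1)c1cccc(Oc2ccc3c(c2)c(=O)ncn3Cc2c(F)cc(F)cc2F)c1C(F)(F)F` is measured in an ADME assay on Caco-2 cells (Homo sapiens) for permeability, in the apical to basolateral direction (on this read-out higher numbers stand for higher permeability and lower numbers for lower permeability), where compound 2 gives 1.2 10^-6 cm/s. Going by the values given here, its only measured neighbour is compound 1 `O=C(Nc1ccccc1)c1cccc(Oc2ccc3c(c2)c(=O)ncn3Cc2c(F)cc(F)cc2F)c1C(F)(F)F`, which in this assay gives 0.84 10^-6 cm/s, and the step of a 1.4-fold higher number from compound 1 to compound 2 (0.15 log units; within the scatter) leaves the two within the scatter of each other. Compound 3 `O=c1ncn(Cc2c(F)cc(F)cc2F)c2ccc(Oc3cccc(-c4ccc5[nH]cnc5c4)c3C(F)(F)F)cc12` differs from compound 2 by 1H-benzimidazol-5-yl in place of (pyridin-2-yl)carbamoyl on an aromatic carbon. Among the compounds with values here, no measured step bears directly on this change; the one known step, a 1.4-fold higher number from compound 1 to compound 2 (0.15 log units; within the scatter), swaps only the ring on the amide-type nitrogen and stays within the scatter. Compound 3 is therefore expected to give 1.5 10^-6 cm/s, within 0.5 10^-6 cm/s to 5 10^-6 cm/s, an expected step of a 1.3-fold higher number from compound 2 to compound 3 (0.10 log units; within the scatter) that would remain within the scatter.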

Compound 3, apparent permeability: 0.4 10^-6 cm/s
Beside the measured number, compound 3's estimate is 3.8-fold (0.57 log units) above it; the measured number lies below the stated range.
By their numbers in this assay, from the lowest: compound 3; then compounds 1 and 2 (each within the scatter of the next).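

In this assay, putting 1H-benzimidazol-5-yl in place of the carbamoyl groups on this aromatic carbon, ortho to a trifluoromethyl group, gives a 3.0-fold lower number from compound 2 to compound 3 (0.48 log units; beyond the scatter) and a 2.1-fold lower number from compound 1 to compound 3 (0.32 log units; beyond the scatter). Going by these compounds alone, these are the first steps here beyond the scatter, showing that replacing the whole carbamoyl group moves the number where swapping the ring on its nitrogen did not. Nothing shown explains this drop.

The compounds leave open whether another fused ring joined directly at this carbon would give the same number. They also leave open how a simple amine or a carboxylic acid would read there.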